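Pyrazine to pyridine on the amide nitrogen in two cores

The source may hold more compounds than are shown below. What is called first, only, known or untested is meant among the compounds shown, and "the series" means these compounds.

Compound 1 `Cc1cnc(NC(=O)[C@H](COC(C)C)Oc2ncnc3c2cnn3-c2ccccc2Cl)cn1` gives 2.1 in a physicochemical assay for lipophilicity; a lower number here means a more polar compound, a higher number a more lipophilic compound. Compound 2 `Cc1ccc(NC(=O)[C@H](COC(C)C)Oc2ncnc3c2cnn3-c2ccccc2Cl)nc1` gives 3.9 in this assay; the change is 5-methylpyridin-2-yl in place of 5-methylpyrazin-2-yl on an amide-type nitrogen and the step is a number 1.80 log units higher from compound 1 to compound 2 (beyond the scatter). Within the data shown here, compound 3 `COC[C@H](Oc1ncnc2c1cnn2-c1ncccc1Cl)C(=O)Nc1cnc(C)cn1` gives 1.4 in this assay, the lowest of the three numbers so far; how its core differs from the core of compound 1 is not broken down here. Compound 4 `COC[C@H](Oc1ncnc2c1cnn2-c1ncccc1Cl)C(=O)Nc1ccc(C)cn1` has not yet been measured in this assay; it differs from compound 3 by 5-methylpyridin-2-yl in place of 5-methylpyrazin-2-yl on an amide-type nitrogen, the same change as before, at the same place. Among the measured compounds shown here, a step of a number 1.50 log units higher from compound 3 to compound 4 (beyond the scatter) is expected here, because the single measured instance of this change gave a number 1.80 log units higher from compound 1 to compound 2 (beyond the scatter), with some allowance for the different core. Compound 4 is therefore estimated at 2.9, with a likely range from 2.3 to 3.5.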

Compound 4, distribution coefficient: 2.3
For compound 4 the middle estimate is 0.60 log units above the measured one, and the stated range covers the measured number.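

In this assay, 5-methylpyridin-2-yl in place of 5-methylpyrazin-2-yl on an amide-type nitrogen gives a number 0.90 log units higher from compound 3 to compound 4 (beyond the scatter), the same direction as a number 1.80 log units higher from compound 1 to compound 2 (beyond the scatter) but a smaller step. Across these two cores the direction of the change carries over and its size does not, and two instances set no rule for any further core. Nothing available accounts for the smaller step in the second core.

Open, going by these compounds, is what a phenyl on the amide-type nitrogen would give in either core. Also open, on these data alone, is whether the step keeps its direction with an amine or a carboxylic acid in place of the ring methyl.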